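From hydroxycarbamoyl to 2-(hydroxycarbamoyl)ethenyl on compound 1

The source may report more compounds than this note shows. Statements on the series, on what has been measured and on what is new or still open speak of the compounds shown alone.

Compound 1 `O=C(NO)c1ccc(Oc2no[n+]([O-])c2S(=O)(=O)c2ccccc2)cc1`: 2190 nM
Compound 2 `COc1cc(C(=O)NO)ccc1Oc1no[n+]([O-])c1S(=O)(=O)c1ccccc1`: 3550 nM

Among the measured compounds shown here, in a functional assay on ES2 cells (Homo sapiens) for inhibition, read by MTT assay, with a stated time of 48 h (a lower number here means a stronger inhibitor, a higher number a weaker inhibitor), compound 1 gives 2190 nM, and its one neighbour on the numbers lies within the usual scatter of it. Compound 3 `O=C(/C=C/c1ccc(Oc2no[n+]([O-])c2S(=O)(=O)c2ccccc2)cc1)NO` has not yet been measured. It differs from compound 1 as follows: 2-(hydroxycarbamoyl)ethenyl in place of hydroxycarbamoyl on an aromatic carbon. For the measured compounds named here, the only measured step, a 1.6-fold higher number from compound 1 to compound 2 (0.21 log units; within the scatter), is a different change, methoxy in place of hydrogen on an aromatic carbon, so it bears only loosely and shows no direction. No step beyond the scatter is therefore expected in this assay, though this rests on thin evidence. The expected step is a 1.2-fold lower number from compound 1 to compound 3 (0.09 log units; within the scatter). For compound 3 the estimated value is 1800 nM, with an expected range from 500 nM to 6000 nM.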

Compound 3, half-maximal inhibitory concentration: 24100 nM
Compound 3: middle estimate off by 13-fold (1.13 log units), on the low side; the measured number lies above the stated range.
By their numbers in this assay, from the lowest: compounds 1 and 2 (each within the scatter of the next); then compound 3.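

In this assay, among the compounds shown here, the group on the aromatic carbon para to a large group proves sensitive: 2-(hydroxycarbamoyl)ethenyl in place of hydroxycarbamoyl gives an 11-fold higher number from compound 1 to compound 3 (1.04 log units; beyond the scatter), the first step here beyond the scatter. Hydrogen-bond donor and acceptor counts stay the same across this change, so those counts alone do not track the step. Nothing shown here gives the reason for the rise. As far as these compounds go, whether it goes with the added length or the extra double bond stays open, and a saturated chain ending in hydroxycarbamoyl would separate the two. From the compounds shown here alone, how a carboxylic acid or an amine at this position would behave also remains open.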